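A few compounds are considered here, and "the series" means these few. Any claim that something is new, unique, unknown or untested is made for them only; others in the source may bear on it.

Measured in a functional assay on MCF7 cells (Homo sapiens) for cytotoxicity, read by MTT assay, with a stated time of 4 h; a lower number here means a stronger inhibitor, a higher number a weaker inhibitor:
- compound 1 `CCC(=O)OC[C@H]1O[C@@H](O[C@@H]2OC=C(C(=O)OC)[C@H]3C[C@H](OC(C)=O)[C@H](C)[C@@H]23)[C@H](OC(C)=O)[C@@H](OC(C)=O)[C@@H]1OC(C)=O`: 1.88 ug/mL
- compound 2 `COC(=O)C1=CO[C@@H](O[C@@H]2O[C@H](COC(=O)C=C(C)C)[C@@H](OC(C)=O)[C@H](OC(C)=O)[C@H]2OC(C)=O)[C@@H]2[C@@H](C)[C@@H](OC(C)=O)C[C@H]12`: 1 ug/mL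

Compound 2 lies within the scatter of compound 1, so these two values set no order. Compound 3 `COC(=O)C1=CO[C@@H](O[C@@H]2O[C@H](COC(=O)c3cccc([N+](=O)[O-])c3)[C@@H](OC(C)=O)[C@H](OC(C)=O)[C@H]2OC(C)=O)[C@@H]2[C@@H](C)[C@@H](OC(C)=O)C[C@H]12` is not yet measured and differs from compound 2 by 3-nitrophenyl in place of 2-methylprop-1-en-1-yl on a carbonyl carbon on a carbonyl carbon. For the measured compounds named here, one measured step bears on this place: a 1.9-fold lower number from compound 1 to compound 2 (0.27 log units; within the scatter), with 2-methylprop-1-en-1-yl in place of ethyl on the same carbonyl carbon. That step stays within the scatter, but neither measured compound carries an aromatic ring there, so it is only a weak guide. No change beyond the scatter is expected in this assay for this replacement. The expected step is a 1.3-fold higher number from compound 2 to compound 3 (0.11 log units; within the scatter) with a wide margin. For compound 3 the estimated value is 1.3 ug/mL, with an expected range of 0.45 ug/mL to 3.8 ug/mL.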

Compound 3, half-maximal inhibitory concentration: 1.25 ug/mL
For compound 3 the middle estimate is 1.0-fold (0.02 log units) above the measured one; the range from low to high includes it.
By their numbers in this assay, from the lowest: compounds 2, 3 and 1 (each within the scatter of the next).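

In this assay, for the compounds shown here, an aromatic ring stands on this carbonyl carbon for the first time, and the steps remain small: a 1.3-fold higher number from compound 2 to compound 3 (0.10 log units; within the scatter) and a 1.5-fold lower number from compound 1 to compound 3 (0.18 log units; within the scatter), both within the scatter. Ethyl, 2-methylprop-1-en-1-yl and 3-nitrophenyl therefore set no order at this place, although 3-nitrophenyl brings more heavy atoms and two hydrogen-bond acceptors that 2-methylprop-1-en-1-yl lacks. Nothing further is available to explain this result.

The three compounds leave open whether the nitro group contributes anything here, since a plain phenyl on the same carbonyl carbon would be needed to separate it from the ring. As far as these compounds go, it is also open whether this tolerance extends to a primary amine, a carboxylic acid or a longer alkyl chain at this place.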